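Amide to Urea on a Shared Core

The compounds below may be only part of what the source reports. "The series", "measured", "known", "first", "only" and "open" are said of these compounds alone.

Measured compounds:
compound 1 `COc1cc(-c2nn(-c3cccc(NC(=O)Nc4cc(C(F)(F)F)cc(C(F)(F)F)c4)c3)cc2-c2ccncc2)ccc1Cl` 932 nM
compound 2 `COc1cc(-c2nn(-c3cccc(NC(=O)c4cccc(C(F)(F)F)c4)c3)cc2-c2ccncc2)ccc1Cl` 3310 nM
compound 3 `O=C(Nc1cccc(-n2cc(-c3ccncc3)c(-c3ccc(Cl)c(O)c3)n2)c1)Nc1cc(C(F)(F)F)cc(C(F)(F)F)c1` 1030 nM

In a functional assay on SN12C cells (Homo sapiens) for inhibition, read by sulforhodamine B assay, with a stated time of 48 h (a lower number here means a stronger inhibitor of growth, a higher number a weaker inhibitor of growth), compound 2 gives the highest of the three numbers. Its nearest neighbour is compound 3, which in this assay gives 1030 nM; the furthest is compound 1, which gives 932 nM, and both gaps lie beyond the scatter. Among the measured compounds shown here, the only single-point step among the measured compounds, a 1.1-fold higher number from compound 1 to compound 3 (0.04 log units; within the scatter), concerns a different place on the shared core and is within the scatter, so it says nothing about the change at hand.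

Compound 4 `COc1cc(-c2nn(-c3cccc(NC(=O)Nc4ccc(Cl)c(C(F)(F)F)c4)c3)cc2-c2ccncc2)ccc1Cl` is not yet measured. Its difference from compound 2 is (4-chloro-3-(trifluoromethyl)phenyl)amino in place of 3-(trifluoromethyl)phenyl on a carbonyl carbon. For the measured compounds named here, no measured step bears directly on this change. What the numbers do show is that compound 1, which carries an amino on the carbonyl carbon, gives 932 nM, whereas compound 2, which does not, gives 3310 nM. On that basis compound 4 is expected to give a lower number than compound 2, a step of about a 2.8-fold lower number from compound 2 to compound 4 (0.44 log units; beyond the scatter). The estimate for compound 4 in this assay is 1200 nM, with a range from 500 nM to 3000 nM.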

Compound 4, concentration for 50% growth inhibition: 1140 nM
The estimate for compound 4 lay 1.1-fold (0.02 log units) above the measured number; the measured number falls inside the stated range.
By their numbers in this assay, from the lowest: compounds 1, 3 and 4 (each within the scatter of the next); then compound 2.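

Among the compounds shown here, on a carbonyl carbon whose other neighbour is an amide-type nitrogen, replacing 3-(trifluoromethyl)phenyl with (4-chloro-3-(trifluoromethyl)phenyl)amino gives the first direct step at this position: in this assay there is a 2.9-fold lower number from compound 2 to compound 4 (0.46 log units; beyond the scatter) and the change turns the amide of compound 2 into a urea. This step also shows that the urea in compound 1 is not alone in giving a lower number than compound 2, since compound 4 at 1140 nM lies within the scatter of compound 1 at 932 nM even though its aromatic ring carries chlorine and one trifluoromethyl rather than two trifluoromethyl groups. Nothing given here accounts for the step, which therefore stands only as a measured difference.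

As far as these compounds go, the step brings in the amino and the chlorine together, so how much of it belongs to each stays open. Also open, from the compounds shown here alone, is how this assay would read with a methylene or an oxygen on the carbonyl carbon in place of that amino, or with a fluorine or a methoxy in place of the chlorine.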